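The source may hold more compounds than are shown below. What is called first, only, known or untested is meant among the compounds shown, and "the series" means these compounds.

Compound 1, `CCCN(CC1CC1)c1nc(C)nc2c(-c3ccc(OC)nc3C)c(C)nn12`, gives 1.6 nM in an assay on cell membranes for displacement of a labelled ligand from corticotropin-releasing factor receptor 1 (Rattus norvegicus); on this read-out higher numbers stand for weaker inhibition and lower numbers for stronger inhibition.
Compound 2, `CCC[C@H](C)Nc1nc(C)nc2c(-c3ccc(OC)nc3C)c(C)nn12`, gives 4.5 nM in this assay.

For the measured compounds named here, compound 2 stands at the higher of the two numbers; its only neighbour is compound 1, reached by the step of a 2.8-fold higher number from compound 1 to compound 2 (0.45 log units; beyond the scatter). Compound 3, `CCN(CC)c1nc(C)nc2c(-c3ccc(OC)nc3C)c(C)nn12`, has not yet been measured; it carries diethylamino in place of (1-methylbutyl)amino on an aromatic carbon. Going by the values given here, the one measured step that bears on this change runs the opposite way, a 2.8-fold higher number from compound 1 to compound 2 (0.45 log units; beyond the scatter), where a tertiary dialkylamino group gave the lower number. Compound 3 is therefore expected to return to a lower number, an estimated step of a 1.8-fold lower number from compound 2 to compound 3 (0.26 log units; within the scatter). The estimate for compound 3 in this assay is 2.5 nM, expected to fall from 1 nM to 7 nM.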

Compound 3, half-maximal inhibitory concentration: 12 nM
Estimate against measurement, compound 3: 4.8-fold (0.68 log units) below; measured number above the stated range.
By their numbers in this assay, from the lowest: compound 1; then compound 2; then compound 3.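

At this aromatic carbon, a tertiary amine alone does not secure the lower number: compound 3, with diethylamino, lies above compound 2, which carries the secondary (1-methylbutyl)amino (a 2.7-fold higher number from compound 2 to compound 3 (0.43 log units; beyond the scatter)). The two tertiary groups also differ clearly in this assay (a 7.5-fold higher number from compound 1 to compound 3 (0.88 log units; beyond the scatter)), so the alkyl groups on the nitrogen matter, not merely the absence of the amine hydrogen. Nothing measured here accounts for this order.

The compounds shown leave open whether dipropylamino would lie nearer compound 1 or compound 3. They also leave open how a cyclic amine such as pyrrolidine would fare at this carbon.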